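Ester for Acid Amide on the Shared Core

The compounds below may be only part of what the source reports. "The series", "measured", "known", "first", "only" and "open" are said of these compounds alone.

Among two compounds tested in an assay on HL-60 cells for agonist activity at vitamin D3 receptor (Homo sapiens), read by microscopy, with a stated time of 96 h (on this read-out lower numbers stand for an effect already at smaller amounts and higher numbers for an effect only at larger amounts of compound), compound 2 `CCn1c(C(=O)N(C)CC(=O)O)ccc1C(CC)(CC)c1ccc(OCC(=O)C(C)(C)C)c(C)c1` gives the highest number, 1390 nM. Within the data shown here, its nearest neighbour, compound 1 `CCN(CC)CCNC(=O)c1ccc(C(CC)(CC)c2ccc(OCC(=O)C(C)(C)C)c(C)c2)n1CC`, gives 91 nM in this assay, and the single measured step, a 15-fold higher number from compound 1 to compound 2 (1.18 log units; beyond the scatter), is large. Compound 3 `CCn1c(C(=O)OCc2ccccn2)ccc1C(CC)(CC)c1ccc(OCC(=O)C(C)(C)C)c(C)c1` has not yet been measured. It differs from compound 2 by (pyridin-2-yl)methoxy in place of (carboxymethyl)(methyl)amino on a carbonyl carbon. Among the measured compounds shown here, only the step from compound 1 to compound 2 bears on this change, and only loosely, since it concerns the same carbonyl carbon but a different replacement; it shows that what sits on this carbonyl carbon can move the number by a large amount. Because a 15-fold higher number from compound 1 to compound 2 (1.18 log units; beyond the scatter) accompanies the entry of the carboxymethyl group, a fall in the number is expected on its removal, though the size is uncertain. The step is estimated as a 9.3-fold lower number from compound 2 to compound 3 (0.97 log units; beyond the scatter). Compound 3 is therefore expected to give about 150 nM, within a range from 30 nM to 700 nM.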

Compound 3, half-maximal effective concentration: > 50000 nM
Compound 3: only a limit was reported; the forecaster's own chance of this, stated with the estimate: 5%; middle value at least 330-fold (2.52 log units) from the limit.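

Compound 3 gives no number on this read-out, only a limit of the assay: the limit of > 50000 nM in this assay, at which 1 of the 3 values shown sits.

With (pyridin-2-yl)methoxy in place of (carboxymethyl)(methyl)amino on the carbonyl carbon, the result is an at least 35-fold higher number from compound 2 to compound 3 (1.55 log units; beyond the scatter), and measured against the (2-(diethylamino)ethyl)amino group the same replacement gives an at least 540-fold higher number from compound 1 to compound 3 (2.73 log units; beyond the scatter). The earlier pair showed only that this position can move the number; now a group without the carboxymethyl unit moves it further in the same direction, so the rise seen with that unit is not specific to it.

The compounds shown leave open whether the oxygen link on the carbonyl carbon or the pyridin-2-yl ring goes with this loss, as the two change together. An amide bearing the same (pyridin-2-yl)methyl group, or an ester bearing a 2-(diethylamino)ethyl group, would separate them.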